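A few compounds are considered here, and "the series" means these few. Any claim that something is new, unique, unknown or untested is made for them only; others in the source may bear on it.

Measured so far in a functional assay on MCF7 cells (Homo sapiens) for antiproliferative activity, read by MTT assay, with a stated time of 72 h; on this read-out higher numbers stand for weaker inhibition and lower numbers for stronger inhibition:
compound 1 `CCN(CC)CCCOc1cc2ncnc(Nc3ccc(C#N)cc3)c2cc1OC` — a limit, > 100000 nM
compound 2 `COc1cc2c(Nc3ccc(C#N)cc3)ncnc2cc1OCCCN1CCCC1` — 16200 nM
compound 3 `COc1cc2c(Nc3ccc(C#N)cc3)ncnc2cc1OCCCN1CCCCC1` — 35100 nM

Compound 3 stands highest of the two numbers in this assay; its nearest neighbour is compound 2, and the step of a 2.2-fold higher number from compound 2 to compound 3 (0.34 log units; beyond the scatter) is modest. Compound 1 gives only a limit, (the limit of > 100000 nM in this assay, at which 1 of the 3 values shown sits), so its steps to the others are bounded: an at least 6.1-fold lower number from compound 1 to compound 2 (0.79 log units; beyond the scatter) and an at least 2.8-fold lower number from compound 1 to compound 3 (0.45 log units; beyond the scatter) are both at least modest. All three steps change only the amine at the end of the propoxy chain.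

Compound 4 `COc1cc2c(Nc3ccc(C#N)cc3)ncnc2cc1OCCCN1CCC(c2ccccc2)CC1` differs from compound 3 by phenyl in place of hydrogen on a saturated ring carbon. For the measured compounds named here, no measured pair adds a phenyl to the piperidine ring; the closest comparisons are the amine swaps above, where the larger amine, compound 3, sits higher than compound 2 by a 2.2-fold higher number from compound 2 to compound 3 (0.34 log units; beyond the scatter) but lower than compound 1 by an at least 2.8-fold lower number from compound 1 to compound 3 (0.45 log units; beyond the scatter). On that basis a step in either direction is possible, and no step beyond the scatter is expected from compound 3 to compound 4 in this assay. The estimated change is a 1.2-fold lower number from compound 3 to compound 4 (0.07 log units; within the scatter). Compound 4 is therefore expected to give about 30000 nM, within roughly 8000 nM to 110000 nM.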

Compound 4, half-maximal inhibitory concentration: 9800 nM
Estimate against measurement, compound 4: 3.1-fold (0.49 log units) above; the range from low to high includes it.
By their numbers in this assay, from the lowest: compounds 4 and 2 (each within the scatter of the next); then compound 3. At a limit, above all of these: compound 1.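

In this assay, a phenyl in place of hydrogen on a saturated ring carbon, three ring bonds from the ring nitrogen, gives a 3.6-fold lower number from compound 3 to compound 4 (0.55 log units; beyond the scatter), so this position of the piperidine ring accepts a six-membered aromatic ring with a modest gain in inhibition. The earlier steps shown here changed only the amine as a whole, and among them piperidin-1-yl sat higher than pyrrolidin-1-yl; with 4-phenylpiperidin-1-yl that gap is gone, at a 1.7-fold lower number from compound 2 to compound 4 (0.22 log units; within the scatter), and compound 2 and compound 4 cannot be ordered. Against compound 1 the change reads as an at least 10-fold lower number from compound 1 to compound 4 (1.00 log units; beyond the scatter), a bound rather than an exact step, as compound 1 is given only as a limit: the limit of > 100000 nM in this assay, at which 1 of the 4 values shown sits.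

From the compounds shown here alone, it stays open whether the gain depends on the aromatic ring itself, since a cyclohexyl, a benzyl or a hydroxyl group on the same ring carbon would separate ring type from size and reach. Going by these compounds, it also stays open whether the phenyl effect carries over to other amines, such as a morpholine or a piperazine, or to a shorter ethoxy chain in place of the propoxy chain.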